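Trimming a Benzyl to a Phenyl on a Thiosemicarbazone

A few compounds are considered here, and "the series" means these few. Any claim that something is new, unique, unknown or untested is made for them only; others in the source may bear on it.

Three compounds have been tested so far in a functional assay on HT-29 cells (Homo sapiens) for antiproliferative activity, read by sulforhodamine B assay, with a stated time of 72 h; on this read-out higher numbers stand for weaker inhibition and lower numbers for stronger inhibition:
Compound 1, `S=C(N/N=C/c1ccc2ccccc2n1)Nc1ccc(Br)cc1`, gives 54400 nM.
Compound 2, `Cc1ccc(NC(=S)N/N=C/c2ccc3ccccc3n2)cc1`, gives 85500 nM.
Compound 3, `S=C(NCc1ccccc1)N/N=C/c1ccc2ccccc2n1`, gives 75700 nM.

All three share the same core and differ only in the group attached to the amide-type nitrogen next to the thiocarbonyl carbon. The numbers cluster tightly: the step of a 1.6-fold higher number from compound 1 to compound 2 (0.20 log units; within the scatter), the step of a 1.4-fold higher number from compound 1 to compound 3 (0.14 log units; within the scatter) and the step of a 1.1-fold lower number from compound 2 to compound 3 (0.05 log units; within the scatter) all fall within the scatter of repeated measurements. On these numbers compound 3 has the second highest value, nearest to compound 2 and furthest from compound 1, yet neither gap is large enough to count as a real difference.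

The next compound, compound 4, `S=C(N/N=C/c1ccc2ccccc2n1)Nc1ccccc1`, differs from compound 3 by phenyl in place of benzyl on an amide-type nitrogen. The two earlier swaps at this same nitrogen, a 1.4-fold higher number from compound 1 to compound 3 (0.14 log units; within the scatter) and a 1.1-fold lower number from compound 2 to compound 3 (0.05 log units; within the scatter), both stayed within the scatter, so no step beyond the scatter is expected in this assay for this further swap either. Compound 4 is therefore estimated at 70000 nM, with a range from 35000 nM to 140000 nM, which means an expected step of a 1.1-fold lower number from compound 3 to compound 4 (0.03 log units; within the scatter).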

Compound 4, half-maximal inhibitory concentration: 17000 nM
The estimate for compound 4 lay 4.1-fold (0.61 log units) above the measured number; measured number below the stated range.
By their numbers in this assay, from the lowest: compound 4; then compounds 1, 3 and 2 (each within the scatter of the next).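

In this assay, going by these compounds alone, phenyl is the first group at this amide-type nitrogen to move the number beyond the scatter: a 4.5-fold lower number from compound 3 to compound 4 (0.65 log units; beyond the scatter) shows that trimming benzyl, with 7 heavy atoms, to phenyl, with 6, is not a neutral swap. The bare ring also matters, as a 5.0-fold lower number from compound 2 to compound 4 (0.70 log units; beyond the scatter) and a 3.2-fold lower number from compound 1 to compound 4 (0.51 log units; beyond the scatter) show that hydrogen on that aromatic carbon gives a lower number than either methyl or bromo. No measurement here accounts for these steps.

Going by these compounds, it stays open whether any other group on the phenyl ring, such as a hydroxyl or an amine, could keep the lower number. On these data alone, it is also open whether a longer chain, such as phenethyl, or a simple alkyl chain with no ring at this nitrogen would fall in line with benzyl or with phenyl.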